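A dimethoxyphenyl swap on an oxime ester already at its limit

A few compounds are considered here, and "the series" means these few. Any claim that something is new, unique, unknown or untested is made for them only; others in the source may bear on it.

Compound 1 `CC1(C)C/C(=N\OC(=O)c2cccc(NC(=O)c3cccc(F)c3)c2)c2c(-c3ccc(F)cc3)noc2C1` gives 5200 nM in a functional assay on MCF7 cells (Homo sapiens) for antiproliferative activity, read by MTT assay, with a stated time of 72 h; a higher number here means a weaker inhibitor, a lower number a stronger inhibitor. Compound 2 `COc1ccc(-c2noc3c2/C(=N/OC(=O)c2cccc(NC(=O)c4cccc(F)c4)c2)CC(C)(C)C3)cc1OC` carries 3,4-dimethoxyphenyl in place of 4-fluorophenyl on an aromatic carbon and reaches only a limit of the assay in this assay, reported as > 25000 nM. That change made an at least 4.8-fold higher number from compound 1 to compound 2 (0.68 log units; beyond the scatter), ending at the limit of > 25000 nM in this assay, at which 2 of the 3 values shown sit. Compound 3 `Nc1cccc(C(=O)Nc2cccc(C(=O)O/N=C3\CCCc4onc(-c5ccc(F)cc5)c43)c2)c1` likewise shows only a limit in this assay, reported as > 25000 nM. How the core of compound 3 differs from the core of compound 1 is not broken down here. Compound 4 `COc1ccc(-c2noc3c2/C(=N/OC(=O)c2cccc(NC(=O)c4cccc(N)c4)c2)CCC3)cc1OC` stands to compound 3 as compound 2 stands to compound 1, through the same change, (3,4-dimethoxyphenyl in place of 4-fluorophenyl on an aromatic carbon). That change gave an at least 4.8-fold higher number from compound 1 to compound 2 (0.68 log units; beyond the scatter) from a measurable start, whereas compound 3 begins already at a limit. On that basis the expected step is a step that the limit leaves unreadable from compound 3 to compound 4. Compound 4 is estimated at 45000 nM, from 25000 nM to 120000 nM.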

Compound 4, half-maximal inhibitory concentration: 25000 nM
Compound 4: the middle estimate sits 1.8-fold (0.26 log units) above what was measured; measured number inside the range.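

In this assay, 3,4-dimethoxyphenyl in place of 4-fluorophenyl did not give matching steps on the two cores: the same change on two cores in this assay, an at least 4.8-fold higher number (0.68 log units; beyond the scatter) from compound 1 to compound 2 and a number no higher (the limit leaves the size open) from compound 3 to compound 4, at least 4.8-fold (0.68 log units) apart, beyond the scatter of two such steps. Compound 3 stands only at a limit of the assay, > 25000 nM. The change gave a number no higher from compound 3 to compound 4 (the limit leaves the size open), and the size of that step cannot be read. The pair therefore shows that the rise seen on the core of compound 1 does not reappear as a readable rise here, but not that the change is harmless or how large its effect is on this second core: the limit of > 25000 nM in this assay, at which 2 of the 4 values shown sit.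

The compounds shown leave open how the change behaves on a core with a measurable start below that limit. They also leave open whether an amine or a carboxylic acid in place of 4-fluorophenyl on that aromatic carbon would alter the number.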